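A Fluorinated Benzyl Variant of a Bombesin Receptor Agonist

The compounds below may be only part of what the source reports. "The series", "measured", "known", "first", "only" and "open" are said of these compounds alone.

Among the compounds with values here, compound 1 `Cc1ccccc1Cc1cnc(CCc2ccc(-c3ccccc3C(=O)O)cc2)[nH]1` shows the higher of the two numbers known so far: in an in vitro functional assay on cells for agonist activity at Bombesin receptor subtype-3 (Homo sapiens), read by luminescence and calcium flux (on this read-out higher numbers stand for an effect only at larger amounts of compound and lower numbers for an effect already at smaller amounts), compound 1 gives 127 nM, while compound 2 `CCC(C)(C)Cc1c[nH]c(CCc2ccc(-c3ccccc3C(=O)O)cc2)n1` gives 25 nM in this assay. Compound 3 `O=C(O)c1ccccc1-c1ccc(CCc2ncc(Cc3cccc(F)c3)[nH]2)cc1` differs from compound 1 by a single change, (3-fluorophenyl in place of 2-methylphenyl on a saturated chain carbon bound to an aromatic carbon). No measured step of this kind exists among these compounds, so a 1.2-fold higher number from compound 1 to compound 3 (0.07 log units; within the scatter) is expected to be small, most likely within the scatter or a slight rise toward weaker activity. Compound 3 is therefore estimated at 150 nM in this assay, with a range from 50 nM to 450 nM.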

Compound 3, half-maximal effective concentration: 159 nM
Compound 3: the middle estimate sits 1.1-fold (0.03 log units) below what was measured; measured number inside the range.
By their numbers in this assay, from the lowest: compound 2; then compounds 1 and 3 (each within the scatter of the next).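

In this assay the exchange of 3-fluorophenyl for 2-methylphenyl on a saturated chain carbon bound to an aromatic carbon gives a 1.3-fold higher number from compound 1 to compound 3 (0.10 log units; within the scatter), so the 2-methylbenzyl and 3-fluorobenzyl groups cannot be told apart at this position. The two groups differ both in the substituent and in where it sits on the ring, and this single step cannot separate those two differences. Nothing available explains this result.

On these data alone, it remains open whether 2-fluorophenyl or 3-methylphenyl would read the same at this place. Also open, as far as these compounds go, is how a phenyl ring carrying an amine or a carboxylic acid would behave here.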